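The source may report more compounds than this note shows. Statements on the series, on what has been measured and on what is new or still open speak of the compounds shown alone.

Measured so far:
- Compound 1 `O=c1cc(CNCc2cccc(I)c2)oc2ccc(O)c(O)c12` in an ADME assay on Huh-7 cells (Homo sapiens) for cytotoxicity (a lower number here means that less compound is tolerated, a higher number that more compound is tolerated), gives > 100000 nM, a limit of the assay and not a number.
- Compound 2 `O=c1cc(CNCc2ccc(I)cc2)oc2ccc(O)c(O)c12` in this assay gives 41700 nM.
- Compound 3 `O=c1cc(CNCc2ccc([N+](=O)[O-])cc2)oc2ccc(O)c(O)c12` in this assay gives 73300 nM.

Compound 3 stands highest of the two numbers, though its gap to compound 2, a 1.8-fold higher number from compound 2 to compound 3 (0.24 log units; within the scatter), is within the scatter. Compound 1 contributes only a limit, (the limit of > 100000 nM in this assay, at which 1 of the 3 values shown sits).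

Compound 4 `Cc1ccc(CNCc2cc(=O)c3c(O)c(O)ccc3o2)cc1` differs from compound 3 by methyl in place of nitro on an aromatic carbon. Among the compounds with values here, the one measured step at that same aromatic carbon is a 1.8-fold higher number from compound 2 to compound 3 (0.24 log units; within the scatter), within the scatter; the other, an at least 2.3-fold lower number from compound 1 to compound 2 (0.37 log units; beyond the scatter), is a different kind of change and bears less on this swap. No step beyond the scatter is therefore expected for compound 4, and a limit remains possible. Compound 4 is estimated at 70000 nM (range 30000 nM to 160000 nM), an expected step of a 1.0-fold lower number from compound 3 to compound 4 (0.02 log units; within the scatter).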

Compound 4, half-maximal cytotoxic concentration: > 100000 nM
Compound 4: no number, only a limit; the forecaster's own chance of this, stated with the estimate: 25%; middle value at least 1.4-fold (0.15 log units) from the limit.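

Methyl is the first group at this aromatic carbon whose compound gives a limit of the assay and not a number: the limit of > 100000 nM in this assay, at which 2 of the 4 values shown sit. Methyl in place of iodo gives an at least 2.3-fold higher number from compound 2 to compound 4 (0.37 log units; beyond the scatter), the first step beyond the scatter at this carbon, while methyl in place of nitro gives an at least 1.3-fold higher number from compound 3 to compound 4 (0.13 log units; that floor lies within the scatter). The step between compound 1 and compound 4 cannot be read, as both values are limits.

Going by these compounds, the true size of the methyl steps stays open. So does where an amine or a carboxylic acid at this aromatic carbon would fall in this assay.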